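Amine-to-triazole swap on the benzylic carbon of the core

The source may report more compounds than this note shows. Statements on the series, on what has been measured and on what is new or still open speak of the compounds shown alone.

Measured so far:
compound 1 `CCN(Cc1ccc(-c2ccnc3ccc(-c4cnc(OC)c(NS(=O)(=O)c5ccc(F)cc5F)c4)cc23)cc1)C1CCCCC1`, 223 nM
compound 2 `COc1ncc(-c2ccc3nccc(-c4ccc(CN5CCN(C(C)C)CC5)cc4)c3c2)cc1NS(=O)(=O)c1ccc(F)cc1F`, 24.7 nM

Both compounds were read in a functional assay on HCT-116 cells (Homo sapiens) for cytotoxicity, read by MTT assay, with a stated time of 72 h; a lower number here means a stronger inhibitor, a higher number a weaker inhibitor. Compound 2 holds the lowest number of the two; its nearest neighbour is compound 1, and the step of a 9.0-fold lower number from compound 1 to compound 2 (0.96 log units; beyond the scatter) lies beyond the scatter. That step is the only one on hand, and it exchanges one saturated amine for another at the same place.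

Compound 3 `COc1ncc(-c2ccc3nccc(-c4ccc(Cn5cncn5)cc4)c3c2)cc1NS(=O)(=O)c1ccc(F)cc1F` differs from compound 2 by 1H-1,2,4-triazol-1-yl in place of 4-isopropylpiperazin-1-yl on a saturated chain carbon bound to an aromatic carbon. For the measured compounds named here, no measured step covers a change of this kind; the step from compound 1 to compound 2 shows only that the group on this carbon can move the number by a modest amount. The exchange here goes further than that step. A loss beyond the scatter is expected for compound 3, and the estimate is 180 nM (range 40 nM to 800 nM), which means a step of a 7.3-fold higher number from compound 2 to compound 3 (0.86 log units; beyond the scatter).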

Compound 3, half-maximal inhibitory concentration: 8.7 nM
Estimate against measurement, compound 3: 21-fold (1.32 log units) above, outside the stated range (below it).
By their numbers in this assay, from the lowest: compound 3; then compound 2; then compound 1.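

In this assay, the 1H-1,2,4-triazol-1-yl group brings a gain (a 2.8-fold lower number from compound 2 to compound 3 (0.45 log units; beyond the scatter)), and the gain is larger against the open-chain amine (a 26-fold lower number from compound 1 to compound 3 (1.41 log units; beyond the scatter)), which leaves compound 3 the strongest of the three. On this saturated chain carbon bound to an aromatic carbon, then, a low number does not depend on a saturated amine, and a five-membered aromatic ring with 3 hetero atoms does better than either amine shown. Nothing at hand explains the shift.

As far as these compounds go, whether the gain is specific to the 1,2,4-triazole or extends to other five-membered aromatic rings, such as imidazole, pyrazole or tetrazole, remains open. Also open, from the compounds shown here alone, is whether a six-membered aromatic ring such as pyridine, or a longer chain between this ring and the core, would keep the number this low.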